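A few compounds are considered here, and "the series" means these few. Any claim that something is new, unique, unknown or untested is made for them only; others in the source may bear on it.

Measured in a functional assay on the whole organism (strain Swiss albino) for inhibition, with Mus musculus as the target, read by paw edema, with stated times of 30 min and 270 min, at a dose of 100 mg/kg by the subcutaneous route; on this read-out higher numbers stand for more inhibition at the one dose given (going by the name of the read-out) and lower numbers for less inhibition:
compound 1 `CCOC(=O)C1CCN(C(=O)c2cc(-c3ccc(C)cc3)nn2Cc2ccccc2)CC1` gives 54.4%
compound 2 `CCCCCCCOc1ccc(OC(=O)c2cc(-c3ccc(C)cc3)nn2Cc2ccccc2)cc1` gives 10%

Compound 2 stands lowest of the two numbers in this assay; its nearest neighbour is compound 1, whose value lies higher by a gap beyond the usual scatter. Among the measured compounds shown here, no step between measured compounds that differ in one place is available, so the change from compound 2 to compound 3 `Cc1ccc(-c2cc(C(=O)Oc3ccc(-n4ccnc4)cc3)n(Cc3ccccc3)n2)cc1` has no measured precedent in this set. The change is 1H-imidazol-1-yl in place of heptyloxy on an aromatic carbon. For the measured compounds named here, with only two measured compounds and no comparable change among them, a step of moderate size in either direction cannot be excluded. The expectation leans toward a rise because compound 1 gives 54.4% on the same shared core. Compound 3 is estimated at 30%, expected to fall between 5% and 60%. The step expected is a number 20 percentage points higher from compound 2 to compound 3 (beyond the scatter).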

Compound 3, a percentage reported as inhibition, in the whole organism at one dose (the size of the read-out at that dose, not a potency): 19.2%
The estimate for compound 3 lay 10.8 percentage points above the measured number; measured number inside the range.
By their numbers in this assay, from the lowest: compounds 2 and 3 (each within the scatter of the next); then compound 1.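

Working from this assay, 1H-imidazol-1-yl in place of heptyloxy, on the aromatic carbon para to a large group, gives a number 9.2 percentage points higher from compound 2 to compound 3 (within the scatter). Among the compounds shown here, this is the first reading of a single change, and it shows that an open chain without a ring and a five-membered aromatic ring with 2 hetero atoms cannot be told apart at this position at the one dose given. Nothing measured on these compounds gives a reason for this result.

On these data alone, whether any group at this position moves the number beyond the scatter remains open, with a primary amine, a carboxylic acid and a shorter alkoxy chain such as methoxy as untested cases here. These two compounds also leave open whether the same swap would read alike on a core carrying another link in place of the ester.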